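Working notes: compound 1 to compound 3 phenyl swap

This account rests on a few compounds, and the source may have more. Where it says the series, first, only, none or still open, it means among the compounds named here.

Measured so far:
compound 1 `NC1=NC2(CCOCC2)N(OCCCOc2ccc(Cl)cc2)C(N)=N1` gives "not determined" (no result reported) in an assay on isolated protein for inhibition of Dihydrofolate reductase (Homo sapiens), read by spectrophotometry, using NADPH, with stated times of 5 s and 6 min, tested at 50 uM; on this read-out higher numbers stand for a stronger effect at the one concentration tested and lower numbers for a weaker effect
compound 2 `NC1=NC2(CCSCC2)N(OCCCOc2cccc(Cl)c2Cl)C(N)=N1` gives 89.8% in this assay

Compound 1 stands nowhere on the numbers: it carries no result in this assay, so there is no single figure to place it against. Compound 2 is the only measured point, and its value shows strong inhibition at the one concentration tested; compound 2 differs from compound 1 in more than one place, so its value is taken only as a reading of what this series can reach.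

Compound 3 `NC1=NC2(CCOCC2)N(OCCCOc2ccccc2Br)C(N)=N1` is to be measured. The change from compound 1 is 2-bromophenyl in place of 4-chlorophenyl on an oxygen on a saturated carbon — 2-bromophenyl in place of 4-chlorophenyl on an oxygen on a saturated carbon. Going by the values given here, with no measured step to go by, the expectation for this assay is a step of no more than the usual scatter, in no fixed direction. Compound 3 is therefore estimated at 80%, within 55% to 96%, a figure expected to sit not far from what compound 2 shows at 89.8%.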

Compound 3, a percentage reported as inhibition, at one concentration (the size of the read-out at that concentration, not a potency): 85%
The estimate for compound 3 lay 5 percentage points below the measured number; the range from low to high includes it.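

No step can be read from compound 1 to compound 3: in this assay compound 1 gives "not determined" (no result reported), so compound 3 at 85% has no partner value. The compounds shown leave open how 2-bromophenyl in place of 4-chlorophenyl alters the read-out in this assay. No supporting evidence bears on this result.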